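Adding a methoxycarbonyl to the pyridin-4-yl of compound 1

This account rests on a few compounds, and the source may have more. Where it says the series, first, only, none or still open, it means among the compounds named here.

Three compounds have been measured in an assay for inhibition of Fatty-acid amide hydrolase 1 (Rattus norvegicus); a lower number here means a stronger inhibitor, a higher number a weaker inhibitor:
compound 1 `O=C(CCc1ccc(-c2ccccc2)cc1)c1ncc(-c2ccncc2)o1` gives 2.3 nM
compound 2 `CNC(=O)c1cnc(C(=O)CCc2ccc(COc3ccccc3)cc2)o1` gives 3.6 nM
compound 3 `CN(C)C(=O)c1cnc(C(=O)CCc2ccc(COc3ccccc3)cc2)o1` gives 6.7 nM

Compound 1 has the lowest number of the three, and so the strongest inhibition shown here, but its distance to compound 2 lies within the usual scatter, so the two cannot be ordered; only compound 3 stands clearly apart from it. Among the compounds with values here, the one step between measured compounds, a 1.9-fold higher number from compound 2 to compound 3 (0.27 log units; within the scatter), concerns the amide end of the core and stays within the scatter.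

Compound 4 `COC(=O)c1cc(-c2cnc(C(=O)CCc3ccc(-c4ccccc4)cc3)o2)ccn1` differs from compound 1 in a single place: methoxycarbonyl in place of hydrogen on an aromatic carbon. Cut one bond further out, the change reads pyridin-4-yl to 2-(methoxycarbonyl)pyridin-4-yl. Within the data shown here, no measured pair touches this part of the molecule, so the only guide is that the small change from compound 2 to compound 3 moved the number little. Without a closer precedent, the expected step of a 1.5-fold higher number from compound 1 to compound 4 (0.18 log units; within the scatter) is small and its direction uncertain. Compound 4 is therefore estimated at 3.5 nM in this assay, with a range from 1 nM to 12 nM.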

Compound 4, inhibition constant: 1.5 nM
Compound 4: the middle estimate sits 2.3-fold (0.37 log units) above what was measured; measured number inside the range.
By their numbers in this assay, from the lowest: compounds 4, 1, 2 and 3 (each within the scatter of the next, the first and the last beyond it).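

In this assay the change brings a 1.5-fold lower number from compound 1 to compound 4 (0.19 log units; within the scatter) and so compound 1 and compound 4 cannot be ordered. Within the data shown here, this is the first reading at this part of the molecule, and it shows that a methoxycarbonyl, with its 4 heavy atoms and 2 hydrogen-bond acceptors, can stand on this aromatic carbon, next to the ring nitrogen, without a step beyond the usual scatter, so the added group neither clearly helps nor clearly harms inhibition here. Nothing at hand explains why the number stays so close to that of the plain pyridin-4-yl.

From the compounds shown here alone, one group at one place is a narrow test, so it remains open whether a carboxylic acid, a primary amide, an amine or a longer ester chain would be accepted on this same carbon as well. Going by these compounds, it is equally open whether a methoxycarbonyl on a different carbon of this ring would give a similar number, or whether this position matters more than this single step suggests.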